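Extending the shared core: from methyl to 4-chlorophenyl

A few compounds are considered here, and "the series" means these few. Any claim that something is new, unique, unknown or untested is made for them only; others in the source may bear on it.

Measured so far:
compound 1 `Cc1noc(-c2cc3cc(F)ccc3[nH]2)n1`: 12400 nM
compound 2 `Cc1noc(-c2cc3cc(Cl)ccc3[nH]2)n1`: 34400 nM

Both compounds were tested in a functional assay on MCF7 cells (Homo sapiens) for antiproliferative activity, read by WST assay, with a stated time of 72 h; a higher number here means a weaker inhibitor, a lower number a stronger inhibitor. For the measured compounds named here, compound 2 holds the highest of the two numbers; its nearest neighbour is compound 1, and the only measured step, a 2.8-fold higher number from compound 1 to compound 2 (0.44 log units; beyond the scatter), is modest but beyond the scatter.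

Compound 3 `Clc1ccc(-c2noc(-c3cc4cc(Cl)ccc4[nH]3)n2)cc1` has not yet been measured. It differs from compound 2 in one place: 4-chlorophenyl in place of methyl on an aromatic carbon. Going by the values given here, no measured step concerns this kind of change; the single step between compound 1 and compound 2 swaps one halogen for another on the bicyclic part of the shared core and says nothing about what happens at the five-membered ring. The expectation for compound 3 therefore rests on little more than the values of compound 1 and compound 2 and the size of the group that enters.

Compound 3 is estimated at 15000 nM, within a wide range from 3000 nM to 60000 nM. Among the compounds with values here, that estimate implies a step of a 2.3-fold lower number from compound 2 to compound 3 (0.36 log units; beyond the scatter), an expected change whose direction is uncertain given that no measured step bears on it.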

Compound 3, half-maximal inhibitory concentration: > 50000 nM
Compound 3: no number, only a limit (the forecaster's own chance of this, stated with the estimate: 15%); middle value at least 3.3-fold (0.52 log units) from the limit.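

In this assay compound 3 gives no number, only a limit: > 50000 nM. For the compounds shown here, the earlier compounds showed only a halogen swap on the shared core, whereas this is the first measured change on the aromatic carbon of the five-membered aromatic ring that lies between two ring nitrogen atoms: 4-chlorophenyl in place of methyl gives an at least 1.4-fold higher number from compound 2 to compound 3 (0.16 log units; that floor lies within the scatter), with no sign of a lower number, although the true size of the step stays unknown. All that is known of this change rests on a single limit: the limit of > 50000 nM in this assay, at which 1 of the 3 values shown sits.

The compounds shown leave open how the number responds at this carbon to groups of intermediate size or different kind, such as an ethyl group, an unsubstituted phenyl ring, an amine or a carboxylic acid, so it cannot be told whether methyl is close to the best choice here or whether 4-chlorophenyl is a special case. They also leave open whether 4-chlorophenyl at this carbon would give a similar result on the fluoro core of compound 1, where the methyl compound has the lower number of the two measured.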